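The compounds below may be only part of what the source reports. "The series", "measured", "known", "first", "only" and "open" are said of these compounds alone.

Compound 1 `CCn1c(=O)/c(=C2\Sc3ccc(C)cc3N2C)s/c1=C\c1ccncc1Nc1ccccc1Cl` gives 650 nM in a functional assay on MCF7 cells (Homo sapiens) for inhibition (on this read-out lower numbers stand for stronger inhibition and higher numbers for weaker inhibition), and stands as the lower of the two numbers recorded so far; its nearest neighbour, compound 2 `CCn1c(=O)/c(=C2\Sc3ccccc3N2C)s/c1=C\c1ccncc1Nc1ccccc1Cl`, gives 750 nM in this assay, and the step of a 1.2-fold higher number from compound 1 to compound 2 (0.06 log units; within the scatter) is within the scatter. Compound 3 `CCn1c(=O)/c(=C2\Sc3ccc(C)cc3N2C)s/c1=C\c1ccncc1Nc1ccccc1F` differs from compound 1 by fluoro in place of chloro on an aromatic carbon. Among the compounds with values here, no measured step touches this position; the only step recorded sits elsewhere on the shared core and is within the scatter, so it gives no direction. A step of no more than the scatter is expected, with compound 3 estimated at 900 nM (range 350 nM to 2500 nM), a step of a 1.4-fold higher number from compound 1 to compound 3 (0.14 log units; within the scatter) from compound 1 that is expected.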

Compound 3, half-maximal inhibitory concentration: 100 nM
For compound 3 the middle estimate is 9.0-fold (0.95 log units) above the measured one; measured number outside the range, below it.
By their numbers in this assay, from the lowest: compound 3; then compounds 1 and 2 (each within the scatter of the next).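

Unlike the methyl position, where the only earlier step stayed within the scatter, this aromatic carbon of the 2-chlorophenyl group responds to a single-atom change in this assay (a 6.5-fold lower number from compound 1 to compound 3 (0.81 log units; beyond the scatter)). Fluoro in place of chloro is therefore a change that moves the number beyond the scatter on the shared core. No measurement at hand accounts for this step.

The compounds shown leave open how hydrogen, methoxy or a nitrile would read at this carbon. Also open, going by these compounds, is whether the step from chloro to fluoro holds on the core of compound 2.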